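A Single Inverted Stereocentre in a Weakly Cytotoxic Pair

A few compounds are considered here, and "the series" means these few. Any claim that something is new, unique, unknown or untested is made for them only; others in the source may bear on it.

Three compounds sharing one core are considered here, and a functional assay on QGY cells (Homo sapiens) for cytotoxicity, read by MTT assay, with a stated time of 48 h (on this read-out lower numbers stand for stronger inhibition and higher numbers for weaker inhibition), supplies the read-out. Compound 1 `CCOC(=O)[C@]1(C(=O)Nc2ccccc2)C[C@H]1c1cc(OC)c(OC)c(OC)c1` returns only a limit in this test, > 100000 nM, and not a true number. Among the measured compounds shown here, compound 2 `CCOC(=O)[C@@]1(C(=O)NCc2ccc(C)cc2)C[C@H]1c1cc(OC)c(OC)c(OC)c1` gives 26400 nM, the only true number available so far, so it has no measured neighbour to be ranked against.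

The open question is compound 3 `CCOC(=O)[C@]1(C(=O)NCc2ccc(C)cc2)C[C@H]1c1cc(OC)c(OC)c(OC)c1`, a stereoisomer of compound 2. The change is confined to one position: the two compounds have the same atoms and bonds and differ only in configuration as drawn: 1 of 2 stereo elements differ; a stereocentre at a saturated ring carbon is drawn S in compound 2 and R in compound 3. For the measured compounds named here, no atom is gained or lost, and no measured step between two compounds shows how much such an inversion matters in this assay.

The expectation therefore rests on compound 2 at 26400 nM, a modest level of activity that leaves room for a loss. A small weakening is expected, with a real chance that compound 3 also returns only a limit. The estimated step of a 2.3-fold higher number from compound 2 to compound 3 (0.36 log units; beyond the scatter) would lie just beyond the usual scatter. For compound 3 the expected value is 60000 nM, with an estimated range of 18000 nM to 100000 nM.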

Compound 3, half-maximal inhibitory concentration: 32100 nM
Compound 3: the middle estimate sits 1.9-fold (0.27 log units) above what was measured, and the stated range covers the measured number.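

In this assay, going by these compounds, the inversion of the stereocentre at the saturated ring carbon now has a measured size, a 1.2-fold higher number from compound 2 to compound 3 (0.08 log units; within the scatter), so at this weak level of activity the two drawn configurations cannot be told apart, and the comparison tests configuration alone: the fact that compounds 2 and 3 differ only in the configuration as drawn The second reading concerns the group on the amide-type nitrogen, where 4-methylbenzyl in place of phenyl gives an at least 3.1-fold lower number from compound 1 to compound 3 (0.49 log units; beyond the scatter), a real difference whose full size stays unknown. That step rests on a limit and not on a number, since compound 1 gives only a limit: the limit of > 100000 nM in this assay, at which 1 of the 3 values shown sits.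

The compounds shown leave open whether the configuration at this ring carbon would still count for so little in a compound far more active than these, and what inverting the other stereocentre would do. They also leave open how far the read-out would move with a phenethyl group on the amide-type nitrogen, or with a carboxylic acid in place of the ethyl ester.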